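Pyrimidin-5-yl for pyridin-3-yl on the shared core

The source may hold more compounds than are shown below. What is called first, only, known or untested is meant among the compounds shown, and "the series" means these compounds.

Compound 1 `CCn1nc(-c2cccnc2)c2ccccc2c1=O` is the reference point of this set. In an assay on isolated protein (Oryctolagus cuniculus) with Thromboxane-A synthase (Homo sapiens) as the target, tested at 1 uM (on this read-out higher numbers stand for more inhibition at the one concentration tested (going by the name of the read-out) and lower numbers for less inhibition), compound 1 gives 87%, the second highest of the three numbers measured. Compound 2 `CCCCn1nc(-c2cccnc2)c2ccccc2c1=O`, which carries a butyl chain in place of the ethyl group, gives 91%; the step of a number 4 percentage points higher from compound 1 to compound 2 (within the scatter) is within the scatter, so the two compounds cannot be ordered. Compound 3 `O=C(c1cccs1)n1nc(-c2cccnc2)c2ccccc2c1=O`, with a (thiophen-2-yl)carbonyl group on the aromatic nitrogen, gives 37%; the steps of a number 50 percentage points lower from compound 1 to compound 3 (beyond the scatter) and a number 54 percentage points lower from compound 2 to compound 3 (beyond the scatter) are both large and beyond the scatter.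

Compound 4 `CCn1nc(-c2cncnc2)c2ccccc2c1=O` is not yet measured. It differs from compound 1 in one place: pyrimidin-5-yl in place of pyridin-3-yl on an aromatic carbon. Within the data shown here, none of the measured steps touches this position; all three concern the substituent on the aromatic nitrogen of the core, so there is no direct precedent for the heteroaryl exchange. Among the measured compounds shown here, the measured pairs show only that the numbers of the two compounds with an alkyl substituent on that nitrogen are level with each other, while the number of the compound with an acyl group there is much lower.

For the measured compounds named here, with no step bearing on the change, compound 4 is expected to stay near compound 1, with a modest drop more likely than a gain: the estimated step is a number 12 percentage points lower from compound 1 to compound 4 (beyond the scatter). Compound 4 is estimated at 75%, with a range of 45% to 93%.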

Compound 4, a percentage reported as inhibition, at one concentration (the size of the read-out at that concentration, not a potency): 26%
For compound 4 the middle estimate is 49 percentage points above the measured one; measured number below the stated range.
By their numbers in this assay, from the lowest: compound 4; then compound 3; then compounds 1 and 2 (each within the scatter of the next).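

In this assay, the exchange of pyridin-3-yl for pyrimidin-5-yl on an aromatic carbon of the shared core gives a number 61 percentage points lower from compound 1 to compound 4 (beyond the scatter). Among these compounds, this is the first evidence that the heteroaryl group matters as well as the substituent on the aromatic nitrogen: the step is large, as is a number 50 percentage points lower from compound 1 to compound 3 (beyond the scatter), although the two heteroaryl groups have the same number of heavy atoms and differ in one ring atom, a carbon in pyridin-3-yl and a nitrogen in pyrimidin-5-yl. Nothing available explains why this single exchange has such a large effect on the read-out.

Still open, as far as these compounds go, is how phenyl, pyridin-4-yl or pyrazin-2-yl on the same carbon would compare with pyridin-3-yl, which would show whether the effect follows the position of the ring nitrogen or the number of ring nitrogens. From the compounds shown here alone, it is also open whether the same exchange would have a similar effect with the butyl chain of compound 2 on the aromatic nitrogen, and how the step would translate into potency, since this assay reports inhibition at a single concentration.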